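A few compounds are considered here, and "the series" means these few. Any claim that something is new, unique, unknown or untested is made for them only; others in the source may bear on it.

Compound 1: `C=CCN(Cc1cccs1)C(=O)COc1ccc(C)cc1`, 20 nM
Compound 2: `CCN(Cc1cccs1)C(=O)COc1ccccc1`, 1400 nM
Compound 3: `CCN1C(=O)C(Oc2ccc(C)cc2)C1c1cccs1`, "active" (no number reported)
Compound 4: `Cc1ccc(OCC(=O)N(Cc2cccs2)C(C)(C)C)cc1`, not yet measured

All of these compounds were examined in an assay on HEK293 cells for agonist activity at transient receptor potential cation channel subfamily M member 8 (Homo sapiens), read by fluorescence and calcium flux, with a stated time of 15 min; on this read-out higher numbers stand for an effect only at larger amounts of compound and lower numbers for an effect already at smaller amounts. Compound 1 gives 20 nM and stands at the low end of the two numbers available; compound 2 gives 1400 nM, a number far enough from that of compound 1 to lie well beyond the scatter. Compound 3 is reported in this assay only as "active" (no number reported), without a number, so its position relative to the others cannot be fixed. Compound 4 differs from compound 1 in a single place: tert-butyl in place of allyl on an amide-type nitrogen. For the measured compounds named here, no pair among the measured compounds differs in just one place, so this change has no measured counterpart to lean on. The number for compound 4 is expected to rise modestly in this assay, estimated as a step of a 3.0-fold higher number from compound 1 to compound 4 (0.48 log units; beyond the scatter), which may sit at or just beyond the edge of the scatter. Compound 4 is estimated at 60 nM in this assay, with a range from 15 nM to 300 nM.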

Compound 4, half-maximal effective concentration: 11000 nM
Compound 4: the middle estimate sits 180-fold (2.26 log units) below what was measured; measured number above the stated range.
By their numbers in this assay, from the lowest: compound 1; then compound 2; then compound 4.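

In this assay, for the compounds shown here, the group on the amide-type nitrogen turns out to matter greatly: tert-butyl in place of allyl gives a 550-fold higher number from compound 1 to compound 4 (2.74 log units; beyond the scatter), a large step that the earlier compounds, with no pair differing in one place, could not reveal. The change is small by count, with the 3 heavy atoms of allyl giving way to the 4 of tert-butyl, the double bond leaving, and no ring, hydrogen-bond donor, hydrogen-bond acceptor or net charge entering or leaving. No measurement at hand explains why so small a change gives so large a step.

Going by these compounds, whether the step follows from the loss of the double bond or from the branching of tert-butyl remains open. A straight propyl chain or an isopropyl group on the same nitrogen of the core of compound 1 would bear on that question.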